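A few compounds are considered here, and "the series" means these few. Any claim that something is new, unique, unknown or untested is made for them only; others in the source may bear on it.

Compound 1 `COc1ccc(OC)c(NC(=O)c2cc(=O)[nH]c3cc(Br)ccc23)c1`: in a functional assay on KYSE-410 cells (Homo sapiens) for antiproliferative activity, read by MTT assay, with a stated time of 72 h (on this read-out higher numbers stand for weaker inhibition and lower numbers for stronger inhibition), compound 1 gives > 20000 nM, which is a limit of the assay and not a number.
Compound 2 `CC(=O)c1ccc(-c2ccc3c(C(=O)Nc4cccc(F)c4)cc(=O)[nH]c3c2)cc1`: in this assay compound 2 gives > 20000 nM, again a limit of the assay rather than a measured number.

Where compound 2 stands on the numbers shown is therefore only as a limit, and the same holds for the other value, since (the limit of > 20000 nM in this assay, at which 2 of the 2 values shown sit). Nothing in these two values separates compound 2 from compound 1; both simply sit at the limit of this assay.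

Compound 3 `O=C(Nc1cccc(F)c1)c1cc(=O)[nH]c2cc(-c3ccc(F)c(CO)c3)ccc12` is not yet measured. It differs from compound 2 in one place, (4-fluoro-3-(hydroxymethyl)phenyl in place of 4-acetylphenyl on an aromatic carbon). Among the measured compounds shown here, no step between two measured compounds is known here, so there is no measured step to lean on for this change. With both measured compounds at the limit in this assay, the step from compound 2 to compound 3 is expected to be none beyond the scatter, as a step that the limit leaves unreadable from compound 2 to compound 3 expresses. For compound 3 the estimate in this assay is 25000 nM, with a range from 6000 nM to 60000 nM.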

Compound 3, half-maximal inhibitory concentration: > 20000 nM
Compound 3: a limit, no number (the forecaster's own chance of this, stated with the estimate: 65%); the middle value is on the limit's open side.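

In this assay compound 3 gives > 20000 nM, which is a limit of the assay and not a number. No step from compound 2 to compound 3 can be read, since both stop at the same limit: the limit of > 20000 nM in this assay, at which 3 of the 3 values shown sit.

The compounds shown leave open whether any of them has measurable activity in this assay, and how 4-fluoro-3-(hydroxymethyl)phenyl compares with 4-acetylphenyl.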